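Vinyl in Place of Methyl on Compound 1

The compounds below may be only part of what the source reports. "The series", "measured", "known", "first", "only" and "open" are said of these compounds alone.

Measured compounds in an ADME assay on MDCK cells (Canis lupus familiaris) for cytotoxicity, read by microscopy, with a stated time of 48 h; on this read-out lower numbers stand for higher toxicity in this test and higher numbers for lower toxicity in this test:
compound 1, `Cc1ccsc1CN[C@@H]1C[C@H]2C[C@@H]([C@H]1C)C2(C)C`, gives 10000 nM
compound 2, `C[C@H]1[C@H](NCc2cncs2)C[C@H]2C[C@@H]1C2(C)C`, gives a limit of the assay, > 100000 nM

For the measured compounds named here, compound 1 is the only compound with a number in this assay; the further value shown is a limit. Compound 2 sits at that limit, (the limit of > 100000 nM in this assay, at which 1 of the 2 values shown sits), and is not a number. Going by the values given here, the single measured step, an at least 10-fold higher number from compound 1 to compound 2 (1.00 log units; beyond the scatter), exchanges one aromatic group for a different one on the saturated chain carbon bound to the amine nitrogen, and is the only step that has been measured.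

Compound 3, `C=Cc1ccsc1CN[C@@H]1C[C@H]2C[C@@H]([C@H]1C)C2(C)C`, differs from compound 1 as follows: vinyl in place of methyl on an aromatic carbon. Among the compounds with values here, no measured step changes a substituent on the five-membered aromatic ring with 1 sulfur while the ring itself stays; the step from compound 1 to compound 2 concerns a different kind of change and does not bear on this one. Compound 3 is therefore expected to show a step of no change at the digits printed from compound 1 to compound 3 (within the scatter), that is, none beyond the scatter. Compound 3 is estimated at 10000 nM, with a range from 3000 nM to 50000 nM.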

Compound 3, minimum cytotoxic concentration: 50000 nM
The estimate for compound 3 lay 5.0-fold (0.70 log units) below the measured number, within the range that was stated.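

In this assay, the exchange of methyl for vinyl on this aromatic carbon gives a 5.0-fold higher number from compound 1 to compound 3 (0.70 log units; beyond the scatter), a modest move towards lower toxicity in this test. The earlier step replaced the whole aromatic group, whereas this one shows that the read-out also responds beyond the scatter to a change of one substituent while the five-membered aromatic ring with 1 sulfur stays, here two ring bonds from the ring sulfur and next to the ring atom that bears a large group. Nothing measured among these compounds explains why the number rises with vinyl in this place.

The compounds shown leave open whether the higher number goes with the double bond of vinyl or simply with the second carbon, a question that an ethyl group on the same aromatic carbon would address. They also leave open how a methoxy group, an amine or a carboxylic acid at this carbon would read in this assay, and whether any of these would carry the number further in the same direction or return it towards that of the methyl compound.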